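A few compounds are considered here, and "the series" means these few. Any claim that something is new, unique, unknown or untested is made for them only; others in the source may bear on it.

Working notes on the series. Compound 1 `O=C(CSc1nc(Nc2ccccc2)c2ccccc2n1)Nc1ccccc1Br` gives 19800 nM in a functional assay on PC-3 cells (Homo sapiens) for inhibition, read by MTT assay, with a stated time of 72 h; a higher number here means a weaker inhibitor, a lower number a stronger inhibitor. Compound 2 `O=C(CSc1nc(Nc2ccccc2)c2ccccc2n1)Nc1cccc([N+](=O)[O-])c1` gives 11800 nM in this assay. Among the compounds with values here, the single step measured so far, a 1.7-fold lower number from compound 1 to compound 2 (0.22 log units; within the scatter), leaves the two numbers within the scatter of each other, so compound 2 stands at the lowest of the two numbers only by a difference that sits inside the scatter. Compound 3 `CCc1cccc(NC(=O)CSc2nc(Nc3ccccc3)c3ccccc3n2)c1` has not yet been measured in this assay; it differs from compound 2 in one place: ethyl in place of nitro on an aromatic carbon. Within the data shown here, no measured step replaces a nitro group with an ethyl group. Among the measured compounds shown here, the only step in hand, a 1.7-fold lower number from compound 1 to compound 2 (0.22 log units; within the scatter), exchanged one substituted phenyl for another on the amide-type nitrogen and stayed within the scatter. On that basis no step beyond the scatter is expected for compound 3, and the expected step of a 1.1-fold higher number from compound 2 to compound 3 (0.04 log units; within the scatter) is small. Compound 3 is estimated at 13000 nM, with a range from 4000 nM to 45000 nM.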

Compound 3, half-maximal inhibitory concentration: 11000 nM
For compound 3 the middle estimate is 1.2-fold (0.07 log units) above the measured one, within the range that was stated.
By their numbers in this assay, from the lowest: compounds 3, 2 and 1 (each within the scatter of the next).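

In this assay, a group carrying hydrogen-bond acceptors gives way to one with none at this place, meta to a large group, and the step stays within the scatter: a 1.1-fold lower number from compound 2 to compound 3 (0.03 log units; within the scatter). With 3-ethylphenyl in place of 2-bromophenyl on the amide-type nitrogen, a 1.8-fold lower number from compound 1 to compound 3 (0.26 log units; within the scatter) is also within the scatter, so the three substituted phenyl groups shown are not separated by this read-out. Nothing measured here bears on why this exchange leaves the number within the scatter.

Going by these compounds, whether an amine, a carboxylic acid or a chain longer than ethyl at this place would give a step beyond the scatter remains open. Also open, on these data alone, is whether any change to the shared core, rather than to this phenyl group, would move the number beyond the scatter.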